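Dihydropyrimidinone ketones at the A2b receptor: cyclopropyl to propyl

The source may hold more compounds than are shown below. What is called first, only, known or untested is meant among the compounds shown, and "the series" means these compounds.

Two compounds of the series carry a number in an assay on membranes from HEK293 cells for displacement of a labelled ligand from adenosine receptor A2b (Homo sapiens), read by scintillation counting, with a stated time of 30 min, tested at 1 uM; a higher number here means more inhibition at the concentration tested (going by the name of the read-out), a lower number less inhibition. Compound 1 `CCCC(=O)C1=C(C)NC(=O)NC1c1ccoc1` gives 22% in this assay. Compound 2 `CC1=C(C(=O)C2CC2)C(c2cccs2)NC(=O)N1` gives 1% in this assay, the lowest of the two numbers, and its nearest neighbour on the numbers is compound 1, a number higher by an amount beyond the scatter.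

Compound 3 `CCCC(=O)C1=C(C)NC(=O)NC1c1cccs1` is not yet measured in this assay. It differs from compound 2 in one place: propyl in place of cyclopropyl on a carbonyl carbon.

Among the measured compounds shown here, no measured pair shows this change on its own, so its size is not known from the series. Compound 3 is expected to rise only modestly over compound 2, by a number 11 percentage points higher from compound 2 to compound 3 (beyond the scatter), a step near the edge of the scatter. Compound 3 is therefore estimated at 12% in this assay, with a range from 0% to 30%.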

Compound 3, a percentage reported as inhibition, at one concentration (the size of the read-out at that concentration, not a potency): 9%
Beside the measured number, compound 3's estimate is 3 percentage points above it; low and high end bracket the measured number.
By their numbers in this assay, from the lowest: compounds 2 and 3 (each within the scatter of the next); then compound 1.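

In this assay the change at the carbonyl carbon now has a measured size, a number 8 percentage points higher from compound 2 to compound 3 (within the scatter) with thiophen-2-yl held constant, so cyclopropyl and propyl are not told apart at this position. The other group does separate a pair: with propyl held constant, thiophen-2-yl in place of furan-3-yl on a saturated ring carbon gives a number 13 percentage points lower from compound 1 to compound 3 (beyond the scatter) in the same read-out. Nothing available accounts for either step.

Open, going by these compounds, is whether a longer chain such as butyl or pentyl, or an amine in place of the propyl group, moves the number at the carbonyl carbon. Also open, on these data alone, is whether the step between furan-3-yl and thiophen-2-yl keeps its size with cyclopropyl on the carbonyl carbon, or whether a phenyl ring on the saturated ring carbon goes beyond either.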